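Trifluoromethoxy for trifluoromethyl: solubility of a urea series

A few compounds are considered here, and "the series" means these few. Any claim that something is new, unique, unknown or untested is made for them only; others in the source may bear on it.

Measured compounds:
compound 1 `O=C(Nc1ccc(OC(F)(F)F)cc1)NC1CCN(C(=O)C2CCCOC2)CC1`, 868 ug/mL
compound 2 `Cc1occc1C(=O)N1CCC(NC(=O)Nc2ccc(OC(F)(F)F)cc2)CC1`, 7.7 ug/mL
compound 3 `Cc1ccoc1C(=O)N1CCC(NC(=O)Nc2ccc(C(F)(F)F)cc2)CC1`, 1.8 ug/mL

In a physicochemical assay for solubility, read by mass spectrometry, in phosphate buffer, with a stated time of 24 h, at pH 3 (a lower number here means a less soluble compound, a higher number a more soluble compound), compound 3 gives 1.8 ug/mL, the lowest of the three numbers; its nearest neighbour is compound 2, and compound 1 stands furthest away. Among the measured compounds shown here, the one change in one place that has been measured, a 110-fold lower number from compound 1 to compound 2 (2.05 log units; beyond the scatter), concerns the amide side of the shared core and does not touch the aryl substituent. Compound 4 `Cc1ccoc1C(=O)N1CCC(NC(=O)Nc2ccc(OC(F)(F)F)cc2)CC1` differs from compound 3 only in that substituent: trifluoromethoxy in place of trifluoromethyl on an aromatic carbon. For the measured compounds named here, no measured step isolates this change. Compound 2, which carries the trifluoromethoxy group but a different furan, gives 7.7 ug/mL against 1.8 ug/mL for compound 3, two changes at once, so the aryl change cannot be separated from the furan change. Compound 4 is therefore expected to stay close to compound 3, with a 1.7-fold higher number from compound 3 to compound 4 (0.22 log units; within the scatter) as the expected step, and its estimated value in this assay is 3 ug/mL, within 0.9 ug/mL to 10 ug/mL.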

Compound 4, solubility: 3.4 ug/mL
Compound 4: middle estimate off by 1.1-fold (0.05 log units), on the low side; the range from low to high includes it.
By their numbers in this assay, from the lowest: compounds 3 and 4 (each within the scatter of the next); then compound 2; then compound 1.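

In this assay the exchange of trifluoromethyl for trifluoromethoxy on an aromatic carbon, para to a large group, can now be read alone: it gives a 1.9-fold higher number from compound 3 to compound 4 (0.28 log units; within the scatter) and so cannot be told apart from repeat measurement. Among the compounds shown here, with trifluoromethoxy held fixed, 3-methylfuran-2-yl in place of 2-methylfuran-3-yl on the carbonyl carbon gives a 2.3-fold lower number from compound 2 to compound 4 (0.36 log units; beyond the scatter), so the arrangement of the furan registers as a modest step. 3-Methylfuran-2-yl in place of oxan-3-yl gives a 260-fold lower number from compound 1 to compound 4 (2.41 log units; beyond the scatter), a large step that, like the one from compound 1 to compound 2, lies on the carbonyl side.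

Nothing available explains these steps. As far as these compounds go, it remains open whether the aryl exchange stays this small with oxan-3-yl on the carbonyl carbon, and how an amine or a carboxylic acid on that aromatic carbon would read.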